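Fluoro for methoxy: cytotoxicity of compound 3

This account rests on a few compounds, and the source may have more. Where it says the series, first, only, none or still open, it means among the compounds named here.

Compound 1 `O=C(/C=C\c1ccc([N+](=O)[O-])cc1)N1N=C(c2ccncc2)OC1c1c[nH]c2ccccc12` and compound 2 `COc1ccc(/C=C\C(=O)N2N=C(c3ccncc3)OC2c2c[nH]c3ccccc23)cc1` share one core and differ only in the group on the aromatic carbon, nitro against methoxy. In an ADME assay on HeLa cells (Homo sapiens) for cytotoxicity, read by MTT assay, with a stated time of 72 h (a lower number here means a stronger inhibitor of growth, a higher number a weaker inhibitor of growth), compound 1 gives only a limit, > 30 ug/mL. In this assay compound 2 likewise gives only a limit, > 30 ug/mL. The step from compound 1 to compound 2 is therefore a step that the two limits leave unreadable from compound 1 to compound 2, and the limit of > 30 ug/mL in this assay, at which 2 of the 2 values shown sit, is all that these two values show.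

Compound 3 `O=C(/C=C\c1ccc(F)cc1)N1N=C(c2ccncc2)OC1c1c[nH]c2ccccc12` is the next member of the series; it differs from compound 2 by fluoro in place of methoxy on an aromatic carbon. Among the compounds with values here, the one measured step, nitro to methoxy, bears on this change only in that both of its ends sit at the limit; its size cannot be read, so no direction in this assay can be taken from it. For compound 3 the expectation is a value at or near the same limit: in this assay compound 3 is estimated at 45 ug/mL, with a range from 20 ug/mL to 110 ug/mL. The step this estimate implies, a step that the limit leaves unreadable from compound 2 to compound 3, is expected to lie within the scatter.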

Compound 3, concentration for 50% growth inhibition: > 30 ug/mL
Compound 3: no number, only a limit (the forecaster's own chance of this, stated with the estimate: 80%); the middle value is on the limit's open side.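

No new step can be read from compound 3 to compound 1 or compound 2, as the result is again a limit and not a number: the limit of > 30 ug/mL in this assay, at which 3 of the 3 values shown sit.

The compounds shown leave open whether nitro, methoxy and fluoro on this aromatic carbon differ at all in this assay, and whether any group there gives the shared core a readable value.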